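Oxazoline to benzothiazole on the shared core: notes

The compounds below may be only part of what the source reports. "The series", "measured", "known", "first", "only" and "open" are said of these compounds alone.

Measured so far in an assay on isolated protein with Polyunsaturated fatty acid 5-lipoxygenase (Homo sapiens) as the target; a higher number here means a weaker inhibitor, a lower number a stronger inhibitor:
compound 1 `CC(=O)c1cc(-c2ccccc2)c2ccc(OCc3cccc(C4(O)CCOCC4)c3)cc2c1` gives 130 nM
compound 2 `COC(=O)c1cc(-c2ccccc2)c2ccc(OCc3cccc(C4(O)CCOCC4)c3)cc2c1` gives 70 nM
compound 3 `OC1(c2cccc(COc3ccc4c(-c5ccoc5)cc(C5=NCCO5)cc4c3)c2)CCOCC1` gives 70 nM

Compound 3 stands level with compound 2 at the digits given, and the two together hold the lowest numbers of the three; compound 1 sits a little higher, but that gap is within the scatter, so no order among the three can be claimed.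

Compound 4 `OC1(c2cccc(COc3ccc4c(-c5ccoc5)cc(-c5nc6ccccc6s5)cc4c3)c2)CCOCC1` is the next step from compound 3. The change is a group of 9 heavy atoms (7 carbon, 1 nitrogen, 1 sulfur; one five-membered aromatic ring with 2 hetero atoms, one six-membered aromatic ring of carbon only) in place of a group of 5 heavy atoms (3 carbon, 1 nitrogen, 1 oxygen; one five-membered non-aromatic ring with 2 hetero atoms), on an aromatic carbon; in words, a 1,3-benzothiazol-2-yl group enters in place of the five-membered non-aromatic ring with two hetero atoms, on an aromatic carbon of the fused six-membered carbon ring, meta to the furan-3-yl group.

Going by the values given here, only one measured step exists in this set, a 1.9-fold lower number from compound 1 to compound 2 (0.27 log units; within the scatter), and it concerns the substituent on the carbonyl carbon of compounds 1 and 2, not the ring replaced here. It gives no guide to an aromatic bicyclic group entering at this position. With nothing bearing directly on the change, the expectation for this assay is a step of no change at the digits printed from compound 3 to compound 4 (within the scatter), that is, no move beyond the scatter, with a wide allowance either way.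

Compound 4 is estimated at 70 nM, in a range from 20 nM to 300 nM.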

Compound 4, half-maximal inhibitory concentration: > 6000 nM
Compound 4: a limit, no number; the forecaster's own chance of this, stated with the estimate: 5%; middle value at least 85-fold (1.93 log units) from the limit.
By their numbers in this assay, from the lowest: compounds 2, 3 and 1 (each within the scatter of the next). At a limit, above all of these: compound 4.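

At the aromatic carbon meta to the furan-3-yl group, the shared core does not tolerate every ring: putting 1,3-benzothiazol-2-yl in place of the five-membered non-aromatic ring gives an at least 85-fold higher number from compound 3 to compound 4 (1.93 log units; beyond the scatter) in this assay. Going by these compounds alone, the one earlier step, a 1.9-fold lower number from compound 1 to compound 2 (0.27 log units; within the scatter), concerned the substituent on a carbonyl carbon and stayed within the scatter, so this is the first change in the set to move the number beyond it. Compound 4 reads as a limit of the assay and not as a number, so the step has a lower bound only and its full size stays unknown: the limit of > 6000 nM in this assay, at which 1 of the 4 values shown sits.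

The change swaps a non-aromatic single ring for a larger aromatic fused pair, and the compounds shown do not separate these two differences, as they include no single aromatic ring at this carbon, such as an oxazole or a thiazole, and no benzoxazole. They also leave open whether an amine or a carboxylic acid on this carbon would stay close to compound 3 at 70 nM.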